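This account rests on a few compounds, and the source may have more. Where it says the series, first, only, none or still open, it means among the compounds named here.

Measured so far in a functional assay on CCRF-CEM cells (Homo sapiens) for cytotoxicity, in the absence of a further agent; a lower number here means a stronger inhibitor, a higher number a weaker inhibitor:
compound 1 `Nc1nc(N)c(CCCN(Cc2ccc(NC(CCC(=O)O)C(=O)O)cc2)c2cc(F)c([N+](=O)[O-])cc2[N+](=O)[O-])c(O)n1` gives 51000 nM
compound 2 `COC(=O)c1ccc(CN(CCCc2c(N)nc(N)nc2O)c2cc(F)c([N+](=O)[O-])cc2[N+](=O)[O-])cc1` gives 4300 nM
compound 3 `Nc1nc(N)c(CCCNc2cc(F)c([N+](=O)[O-])cc2[N+](=O)[O-])c(O)n1` gives 1000 nM

Compound 2 stands second highest of these three numbers. Compound 4 `COC(=O)c1ccc(CN(CCCc2c(N)nc(N)nc2O)c2cc(F)ccc2[N+](=O)[O-])cc1` differs from it by hydrogen in place of nitro on an aromatic carbon (hydrogen in place of nitro on an aromatic carbon, ortho to a fluoro group). The measured steps are a 12-fold lower number from compound 1 to compound 2 (1.07 log units; beyond the scatter) and a 4.3-fold lower number from compound 2 to compound 3 (0.63 log units; beyond the scatter) (one large, one modest). Both changed other parts of the molecule, so they only hint at how far one change can move the number here. A modest step in this assay towards a higher number is expected, though that direction is a weak guess. The estimated change is a 2.1-fold higher number from compound 2 to compound 4 (0.32 log units; beyond the scatter). Nothing in the data so far confirms it. Compound 4 is expected at 9000 nM (estimated range 2500 nM to 35000 nM).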

Compound 4, half-maximal inhibitory concentration: 55000 nM
The estimate for compound 4 lay 6.1-fold (0.79 log units) below the measured number, and the stated range ends below it.
By their numbers in this assay, from the lowest: compound 3; then compound 2; then compounds 1 and 4 (each within the scatter of the next).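

In this assay, putting hydrogen in place of the nitro group ortho to a fluoro group gives a 13-fold higher number from compound 2 to compound 4 (1.11 log units; beyond the scatter). This is the first change shown at this position, and one group alone produces a large step. Compound 4 keeps its other nitro group, yet that does not hold its number near that of compound 2, and nothing measured here explains the rise.

Open, on these data alone, is whether a nitrile or an amine at this position would keep the number close to that of compound 2. Also open, as far as these compounds go, is whether the same change would act alike in compound 3, which lacks the 4-(methoxycarbonyl)benzyl group.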